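The source may hold more compounds than are shown below. What is called first, only, known or untested is meant among the compounds shown, and "the series" means these compounds.

Working notes: in an ADME assay on microsomes from liver (Homo sapiens) for metabolic stability, read by LC-MS, with a stated time of 30 min, tested at 1 uM (a lower number here means that less of the compound is left, a higher number that more of the compound is left), compound 1 `O=C(NCc1ccc(S(=O)(=O)c2ccccc2)cc1)c1cc2ccncc2s1` gives 48%, the lowest reading in the series. Compound 3 `O=C(NCc1ccc(S(=O)(=O)c2ccccc2)cc1)c1cc2cnccc2[nH]1` gives 75%, and the step is a number 27 percentage points higher from compound 1 to compound 3 (beyond the scatter). Compound 2 `O=C(NCc1ccc(S(=O)(=O)c2ccccc2)cc1)c1c[nH]c2ccncc12` reads > 99%, which is a limit of the assay. That step is larger: a number at least 51 percentage points higher from compound 1 to compound 2 (beyond the scatter). Compound 4 `O=C(NCc1ccc(S(=O)(=O)c2cccc(C(F)(F)F)c2)cc1)c1cc2ccncc2s1` differs from compound 1 by trifluoromethyl in place of hydrogen on an aromatic carbon, phenyl to 3-(trifluoromethyl)phenyl. Both measured steps change the group on the carbonyl carbon, so neither covers this change directly, and their size does not carry over. No step beyond the scatter is therefore expected in this assay, though with wide uncertainty. The expected change is a number 2 percentage points higher from compound 1 to compound 4 (within the scatter). For compound 4 the estimate is 50%, with an expected range of 25% to 78%.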

Compound 4, percent of the compound remaining: 43%
Compound 4: middle estimate off by 7 percentage points, on the high side; low and high end bracket the measured number.
By their numbers in this assay, from the lowest: compounds 4 and 1 (each within the scatter of the next); then compound 3. At a limit, above all of these: compound 2.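

Every earlier step changes the group on the carbonyl carbon, whereas trifluoromethyl in place of hydrogen on an aromatic carbon, meta to a large group, changes the far six-membered aromatic ring of carbon only. In this assay this gives a number 5 percentage points lower from compound 1 to compound 4 (within the scatter) and so no readable change at this position, on the core of compound 1 alone. Nothing at hand offers a cause for this result.

Still open, from the compounds shown here alone, is whether the same change holds on the cores of compound 2 and compound 3. Also open, going by these compounds, is how an amine or a carboxylic acid at this position would read.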